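Replacing pyridin-3-yl with 3-chlorophenyl in compound 4

The source may report more compounds than this note shows. Statements on the series, on what has been measured and on what is new or still open speak of the compounds shown alone.

Compound 3 `CCCSc1nc(N/N=C/c2cccnc2)c2nnn(Cc3ccccc3)c2n1` shares its core with two measured analogues. In a functional assay on MGC-803 cells (Homo sapiens) for antiproliferative activity, read by MTT assay, with a stated time of 72 h (on this read-out lower numbers stand for stronger inhibition and higher numbers for weaker inhibition), compound 3 gives 38100 nM, the lower of the two numbers shown, though the gap to its neighbour lies within the scatter. Compound 1 `CCCSc1nc(N/N=C(\C)c2ccc(OC)cc2)c2nnn(Cc3ccccc3)c2n1` gives 44300 nM in this assay. Compound 2 `CCCSc1nc(N/N=C/c2ccc(Cl)cc2)c2nnn(Cc3ccccc3)c2n1` reaches only a limit of > 64000 nM in this assay; that limit is the limit of > 64000 nM in this assay, at which 1 of the 3 values shown sits. Among the compounds with values here, the one step that bears on the new compound is an at least 1.6-fold lower number from compound 2 to compound 3 (0.22 log units; that floor lies within the scatter). Compound 4 `CCCSc1nc(N/N=C/c2cccc(Cl)c2)c2nnn(Cc3ccccc3)c2n1` differs from compound 3 by 3-chlorophenyl in place of pyridin-3-yl on a carbon with a double bond to nitrogen. Because an at least 1.6-fold lower number from compound 2 to compound 3 (0.22 log units; that floor lies within the scatter) ran in the opposite direction, a somewhat higher number is expected for compound 4, amounting to a 1.4-fold higher number from compound 3 to compound 4 (0.16 log units; within the scatter). Compound 4 is therefore estimated at 55000 nM, between 30000 nM and 100000 nM.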

Compound 4, half-maximal inhibitory concentration: > 64000 nM
Compound 4 gave a limit, no number (the forecaster's own chance of this, stated with the estimate: 40%); middle value at least 1.1-fold (0.06 log units) from the limit.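

In this assay, compound 4 joins compound 2 at a limit, not a number, so both chlorophenyl groups tested at this position end at that limit: the limit of > 64000 nM in this assay, at which 2 of the 4 values shown sit. Replacing pyridin-3-yl with 3-chlorophenyl gives an at least 1.6-fold higher number from compound 3 to compound 4 (0.22 log units; that floor lies within the scatter), a floor that does not separate the two groups beyond the scatter. The step between compound 2 and compound 4 cannot be read, so 3-chlorophenyl and 4-chlorophenyl cannot be ranked. From the compounds shown here alone, whether pyridin-4-yl or a phenyl ring carrying an amine or a carboxylic acid would give a number at this position remains open.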